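A few compounds are considered here, and "the series" means these few. Any claim that something is new, unique, unknown or untested is made for them only; others in the source may bear on it.

Measured in a functional assay on CAL-51 cells (Homo sapiens) for antiproliferative activity, read by luminescence and CellTiter-Glo, with a stated time of 3 days; on this read-out higher numbers stand for weaker inhibition and lower numbers for stronger inhibition:

Compound 1 `C[C@@H](Oc1cc(C(=O)N(C)C)ccc1Nc1nc(O[C@H]2CC[C@@](C)(O)CC2)c2cc[nH]c2n1)C(F)(F)F`: 24 nM
Compound 2 `C[C@@H](Oc1cc(C(=O)N(C)C)ccc1Nc1nc(O[C@H]2CC[C@@](C)(O)CC2)c2c(Cl)c[nH]c2n1)C(F)(F)F`: 10 nM
Compound 3 `COc1cc(C(=O)N(C)C)ccc1Nc1nc(OC2CCCCC2)c2cc[nH]c2n1`: 190 nM

Compound 3, at 190 nM, has the highest number of the three, which makes it the weakest inhibitor here. Compound 1 lies nearest to it and compound 2 furthest away. The next compound, compound 4 `COc1cc(C(=O)N(C)C)ccc1Nc1nc(OC2CCOCC2)c2cc[nH]c2n1`, has not yet been measured. It differs from compound 3 in one group: oxan-4-yl in place of cyclohexyl on an oxygen on an aromatic ring. In words, oxan-4-yl stands in place of cyclohexyl on an oxygen on an aromatic ring.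

Going by the values given here, only one single-place step has been measured, a 2.4-fold lower number from compound 1 to compound 2 (0.38 log units; beyond the scatter). It puts chloro in place of hydrogen on an aromatic carbon, a different change at a different place, so it offers only a rough sense of scale. Among the compounds with values here, no measured pair tests the cyclohexyl exchange itself, and compound 1 and compound 3 differ in more than one place. With so little to go on, no step beyond the scatter is expected, with a slight lean towards a higher number. The expected change is a 1.4-fold higher number from compound 3 to compound 4 (0.14 log units; within the scatter). For compound 4 the estimated value is 260 nM, with an expected range from 90 nM to 750 nM.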

Compound 4, half-maximal inhibitory concentration: 198 nM
Beside the measured number, compound 4's estimate is 1.3-fold (0.12 log units) above it; the range from low to high includes it.
By their numbers in this assay, from the lowest: compound 2; then compound 1; then compounds 3 and 4 (each within the scatter of the next).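

In this assay, going by these compounds alone, putting oxan-4-yl in place of cyclohexyl on an oxygen on an aromatic ring gives a 1.0-fold higher number from compound 3 to compound 4 (0.02 log units; within the scatter), the first measured step at this place. The two rings have the same count of 6 heavy atoms, but oxan-4-yl holds 1 oxygen and 1 hydrogen-bond acceptor where cyclohexyl holds none, and this read-out does not separate them. For this one pair, the difference between an all-carbon ring and a ring with 1 hetero atom therefore leaves the antiproliferative numbers within the scatter of each other, though no information on any other property of the pair accompanies this result, and nothing here accounts for it.

The compounds shown leave open whether a ring carrying a basic nitrogen, such as piperidin-4-yl, or an open chain such as a longer alkyl ether would give a similar number at this oxygen. They also leave open whether the same exchange of cyclohexyl for oxan-4-yl would read alike on the chloro-bearing core of compound 2, with its different groups elsewhere.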